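A few compounds are considered here, and "the series" means these few. Any claim that something is new, unique, unknown or untested is made for them only; others in the source may bear on it.

Compound 1, `CC(=O)Nc1ccc2c(c1)S(=O)(=O)C=C(c1c(O)c3cc(F)ccc3n(Cc3ccc(F)cc3)c1=O)N2`: in an ADME assay on 2209-23 cells (Homo sapiens) for cytotoxicity, read by WST assay (on this read-out higher numbers stand for lower toxicity in this test and lower numbers for higher toxicity in this test), compound 1 gives > 50000 nM, which is a limit of the assay rather than a number.
Compound 2, `CS(=O)(=O)Nc1ccc2c(c1)S(=O)(=O)C=C(c1c(O)c3ccccc3n(Cc3ccc(F)cc3)c1=O)N2`: in this assay compound 2 gives > 50000 nM, again only a limit.
Compound 3, `CS(=O)(=O)Nc1ccc2c(c1)S(=O)(=O)C=C(c1c(O)c3c(Cl)cccc3n(Cc3ccc(F)cc3)c1=O)N2`: in this assay compound 3 gives > 50000 nM, also a limit.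

Compound 2 therefore stands nowhere on a scale: it has no measured number, only a limit, and the same holds for the other two compounds, since all of them sit at the limit of > 50000 nM in this assay, at which 3 of the 3 values shown sit. The compound to be judged is compound 4, `COc1ccc2c(c1)c(O)c(C1=CS(=O)(=O)c3cc(NS(C)(=O)=O)ccc3N1)c(=O)n2Cc1ccc(F)cc1`, which arises from compound 2 by methoxy in place of hydrogen on an aromatic carbon.

Within the data shown here, only one measured step touches a change on the shared core, the one from compound 2 to compound 3, and that step is a step that the two limits leave unreadable from compound 2 to compound 3. It gives no size and no direction, so nothing indicates that a small substituent on the core moves toxicity out of the limited region. For the step from compound 2 to compound 4 the expectation is accordingly a number no higher from compound 2 to compound 4 (the limit leaves the size open), no shift beyond the scatter. Compound 4 is thus expected to give 50000 nM, in a range from 25000 nM to 100000 nM, most likely reported once more as a limit.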

Compound 4, half-maximal cytotoxic concentration: > 50000 nM
Compound 4 gave a limit, no number; the forecaster's own chance of this, stated with the estimate: 85%; the middle value sits exactly at the limit.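

No size or direction can be read for the change from compound 2 to compound 4, because both compounds sit at a limit rather than a number: the limit of > 50000 nM in this assay, at which 4 of the 4 values shown sit.

The compounds shown leave open whether chloro or methoxy in place of hydrogen on an aromatic carbon changes toxicity in this assay at all.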